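Amide-nitrogen aryl variation in the catechol ether amide series

This account rests on a few compounds, and the source may have more. Where it says the series, first, only, none or still open, it means among the compounds named here.

Measured so far:
- compound 1 `COc1ccc(C(=O)Nc2c(F)cccc2F)cc1OC1CCCC1`: in an assay on isolated protein for inhibition of phosphodiesterase 4A (Sus scrofa) (on this read-out lower numbers stand for stronger inhibition and higher numbers for weaker inhibition), compound 1 gives 70 nM
- compound 2 `COc1ccc(C(=O)Nc2ccccc2O)cc1OC1CCCC1`: compound 2 gives 1300 nM
- compound 3 `COc1ccc(C(=O)Nc2cccnc2)cc1OC1CCCC1`: compound 3 gives 550 nM

Compound 3 sits second highest of the three numbers, a 7.9-fold higher number from compound 1 to compound 3 (0.90 log units; beyond the scatter) and a 2.4-fold lower number from compound 2 to compound 3 (0.37 log units; beyond the scatter). Compound 4 `COc1ccc(C(=O)Nc2c(C)nsc2C)cc1OC1CCCC1` differs from compound 3 only at the amide-type nitrogen: 3,5-dimethyl-1,2-thiazol-4-yl in place of pyridin-3-yl on an amide-type nitrogen. The three aryl swaps already measured all bear on it: the largest was a 19-fold higher number from compound 1 to compound 2 (1.27 log units; beyond the scatter), the others modest. Among the compounds with values here, no previous compound carries a five-membered ring here, so direction is uncertain; a modest lowering toward compound 1 is expected, a 2.8-fold lower number from compound 3 to compound 4 (0.44 log units; beyond the scatter). Compound 4 is estimated at 200 nM, with a range of 50 nM to 800 nM.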

Compound 4, half-maximal inhibitory concentration: 500 nM
The estimate for compound 4 lay 2.5-fold (0.40 log units) below the measured number, within the range that was stated.
By their numbers in this assay, from the lowest: compound 1; then compounds 4 and 3 (each within the scatter of the next); then compound 2.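

In this assay, replacing the six-membered pyridin-3-yl ring with the five-membered 3,5-dimethyl-1,2-thiazol-4-yl ring on the amide-type nitrogen gives a 1.1-fold lower number from compound 3 to compound 4 (0.04 log units; within the scatter) so ring size and the added sulfur and methyl groups leave no readable change at this pair. The 2,6-difluorophenyl group keeps its lead, with a 7.1-fold higher number from compound 1 to compound 4 (0.85 log units; beyond the scatter) while the other comparison shows a 2.6-fold lower number from compound 2 to compound 4 (0.41 log units; beyond the scatter) and so places the 2-hydroxyphenyl compound highest. No evidence on hand accounts for these numbers.

Open, as far as these compounds go, is how an unsubstituted phenyl, 2,6-dichlorophenyl or 2,6-dimethylphenyl group would compare with the 2,6-difluorophenyl group. Also open, from the compounds shown here alone, is what the 1,2-thiazol-4-yl ring gives without its two methyl groups.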